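Pyridinyl position change on the fluorophenyl core

The source may report more compounds than this note shows. Statements on the series, on what has been measured and on what is new or still open speak of the compounds shown alone.

Measured compounds in a functional assay on MCF7 cells (Homo sapiens) for inhibition, with a stated time of 96 h; on this read-out lower numbers stand for stronger inhibition and higher numbers for weaker inhibition:
- compound 1, `COc1cc(C(=O)c2cn(-c3ccc(C)cc3)cc2-c2cccnc2)cc(OC)c1OC`: 19 nM
- compound 2, `COc1cc(C(=O)c2cn(-c3ccc(C)cc3)cc2-c2ccncc2)cc(OC)c1OC`: 9 nM
- compound 3, `COc1cc(C(=O)c2cn(-c3ccc(F)cc3)cc2-c2cccnc2)cc(OC)c1OC`: 39 nM

Compound 4, `COc1cc(C(=O)c2cn(-c3ccc(F)cc3)cc2-c2ccncc2)cc(OC)c1OC`, is not yet measured in this assay. From compound 3 it differs by pyridin-4-yl in place of pyridin-3-yl on an aromatic carbon. The same kind of change has been measured once, from compound 1 to compound 2, where it reads pyridin-4-yl in place of pyridin-3-yl on an aromatic carbon and gave a 2.1-fold lower number from compound 1 to compound 2 (0.32 log units; beyond the scatter). The two places are not identical: in the measured pair the ring atom two bonds away bears a 4-methylphenyl group, in the new pair a 4-fluorophenyl group. The two cores differ by fluoro in place of methyl on an aromatic carbon, which gave a 2.1-fold higher number from compound 1 to compound 3 (0.31 log units; beyond the scatter). Compound 3 stands highest of the three numbers. Among the compounds with values here, a step of about the same size is expected from compound 3 to compound 4, a 2.1-fold lower number from compound 3 to compound 4 (0.31 log units; beyond the scatter), because the single measured precedent is a 2.1-fold lower number from compound 1 to compound 2 (0.32 log units; beyond the scatter). Compound 4 is therefore estimated at 19 nM in this assay.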

Compound 4, half-maximal inhibitory concentration: 9 nM
Compound 4: middle estimate off by 2.1-fold (0.32 log units), on the high side; the measured number falls inside the stated range.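

In this assay, pyridin-4-yl in place of pyridin-3-yl gives a 4.3-fold lower number from compound 3 to compound 4 (0.64 log units; beyond the scatter), and this step agrees with the one on the core of compound 1: the same change on two cores in this assay, a 2.1-fold lower number (0.32 log units; beyond the scatter) from compound 1 to compound 2 and a 4.3-fold lower number (0.64 log units; beyond the scatter) from compound 3 to compound 4, 2.1-fold (0.31 log units) apart, within the scatter of two such steps. Fluoro in place of methyl gives no change at the digits printed from compound 2 to compound 4 (within the scatter), and this step likewise does not separate from the earlier one: the same change on two cores in this assay, a 2.1-fold higher number (0.31 log units; beyond the scatter) from compound 1 to compound 3 and no change at the digits printed (within the scatter) from compound 2 to compound 4, 2.1-fold (0.31 log units) apart, within the scatter of two such steps. Within the data shown here, each change therefore carries across these two cores within the scatter, but with only two pairs per change this neither fixes the size of either step nor shows that it would hold on any other core.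

Open, going by these compounds, is how a pyridin-2-yl group would read at this place. Also open, on these data alone, is whether a chloro or methoxy group in place of fluoro or methyl would follow the same steps.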